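The source may report more compounds than this note shows. Statements on the series, on what has been measured and on what is new or still open speak of the compounds shown alone.

In a functional assay on SK-BR-3 cells (Homo sapiens) for antiproliferative activity (on this read-out lower numbers stand for stronger inhibition and higher numbers for weaker inhibition), the measured compounds stand as follows. Compound 1 `CC(C)=CCc1cc(C(=O)Nc2cc3ccc(OCC4CCN(C)C4)c(C)c3oc2=O)ccc1O` gives 920 nM. Compound 2 `CCCN(CCC)CCCOc1ccc2cc(NC(=O)c3ccc(O)c(CC=C(C)C)c3)c(=O)oc2c1C` reaches only the limit of the assay, > 50000 nM. Compound 3 `CC(C)=CCc1cc(C(=O)Nc2cc3ccc(OCCCNc4ccccc4)c(C)c3oc2=O)ccc1O` likewise reaches only the limit, > 50000 nM.

Compound 2 thus stands at the limit, as does compound 3 (the limit of > 50000 nM in this assay, at which 2 of the 3 values shown sit). Compound 4 `CC(C)=CCc1cc(C(=O)Nc2cc3ccc(OCCCN[C@H](C)c4ccccc4)c(C)c3oc2=O)ccc1O` differs from compound 2 by (1-phenylethyl)amino in place of dipropylamino on a saturated chain carbon, three bonds along the chain from an oxygen on an aromatic ring. The nearest measured step, a step that the two limits leave unreadable from compound 2 to compound 3, has no readable size; both of its ends are limits. The steps of an at least 54-fold higher number from compound 1 to compound 2 (1.73 log units; beyond the scatter) and an at least 54-fold higher number from compound 1 to compound 3 (1.73 log units; beyond the scatter) show that both changes away from compound 1 are large losses. The expected step from compound 2 onward is an at least 1.2-fold lower number from compound 2 to compound 4 (0.09 log units; that floor lies within the scatter), with no clear direction. Compound 4 is therefore estimated at 40000 nM, between 8000 nM and 150000 nM, with a good chance that only a limit is reported.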

Compound 4, half-maximal inhibitory concentration: 1000 nM
The estimate for compound 4 lay 40-fold (1.60 log units) above the measured number, outside the stated range (below it).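

Replacing dipropylamino with (1-phenylethyl)amino gives an at least 50-fold lower number from compound 2 to compound 4 (1.69 log units; beyond the scatter), and putting 1-phenylethyl in place of phenyl on the amine nitrogen gives an at least 50-fold lower number from compound 3 to compound 4 (1.69 log units; beyond the scatter). An open chain at this place can therefore keep activity, and the group on its amine nitrogen decides the outcome among these compounds, while a 1.1-fold higher number from compound 1 to compound 4 (0.04 log units; within the scatter) puts compound 4 level with the pyrrolidine-bearing compound 1. Both large steps start from a limit rather than a number: the limit of > 50000 nM in this assay, at which 2 of the 4 values shown sit.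

From the compounds shown here alone, whether a benzyl group on the amine nitrogen, or the mirror-image form of 1-phenylethyl, would hold this activity remains open.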